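The compounds below may be only part of what the source reports. "The series", "measured", "known", "first", "only" and "open" are said of these compounds alone.

Three compounds of the series carry numbers in a functional assay on NCI-H460 cells (Homo sapiens) for cytotoxicity, read by resazurin assay, with a stated time of 48 h; a lower number here means a stronger inhibitor, a higher number a weaker inhibitor. Compound 1 `COc1cc(O)c2c(=O)cc(-c3ccc(O)cc3)oc2c1[C@H]1C[C@H](O)[C@H](O)[C@@H](C)O1` gives 46900 nM in this assay. Compound 2 `COc1cc(O)c2c(=O)cc(-c3ccc(O)cc3)oc2c1[C@H]1CC(=O)[C@H](O)[C@@H](C)O1` gives 18100 nM in this assay, the step being a 2.6-fold lower number from compound 1 to compound 2 (0.41 log units; beyond the scatter). Compound 3 `C[C@H]1O[C@@H](c2c(O)cc(O)c3c(=O)cc(-c4ccc(O)cc4)oc23)C[C@H](O)[C@@H]1O` gives 18300 nM in this assay, the step being a 2.6-fold lower number from compound 1 to compound 3 (0.41 log units; beyond the scatter). Compound 3 thus stands second highest of the three numbers; its value and that of compound 2 lie within the scatter of one another, and only compound 1 is separated from it.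

Compound 4 `C[C@H]1O[C@@H](c2c(O)cc(O)c3c(=O)cc(-c4ccc(O)cc4)oc23)C[C@H](O)[C@H]1O` is not yet measured. Relative to compound 3 the change is the two compounds have the same atoms and bonds and differ only in configuration as drawn: 1 of 4 stereo elements differ; a stereocentre at a saturated ring carbon is drawn S in compound 3 and R in compound 4. Among the measured compounds shown here, neither measured step bears on this: a 2.6-fold lower number from compound 1 to compound 2 (0.41 log units; beyond the scatter) swaps one six-membered non-aromatic ring group for another, and a 2.6-fold lower number from compound 1 to compound 3 (0.41 log units; beyond the scatter) puts hydrogen in place of methyl on an oxygen; no step in the set inverts a stereocentre at a saturated ring carbon. With nothing to anchor a direction, the step of a 1.0-fold lower number from compound 3 to compound 4 (0.01 log units; within the scatter) is expected to lie within the scatter. Compound 4 is therefore estimated at 18000 nM, with a range of 7000 nM to 50000 nM.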

Compound 4, half-maximal inhibitory concentration: 12000 nM
Beside the measured number, compound 4's estimate is 1.5-fold (0.18 log units) above it, within the range that was stated.
By their numbers in this assay, from the lowest: compounds 4, 2 and 3 (each within the scatter of the next); then compound 1.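

In this assay, inverting a stereocentre at a saturated ring carbon, drawn S in compound 3 and R in compound 4, gives a 1.5-fold lower number from compound 3 to compound 4 (0.18 log units; within the scatter). Among the compounds shown here, the earlier steps changed a six-membered ring group and a methyl on an oxygen, so this is the first reading of configuration, and at this stereocentre the inversion leaves the number within the scatter. The comparison has no other structural difference to weigh: the fact that compounds 3 and 4 differ only in the configuration as drawn.

As far as these compounds go, whether inversion at the other stereocentres would read the same remains open, as does the same inversion with the methyl on the oxygen of compound 1 present. Also open, from the compounds shown here alone, is how an amine in place of a hydroxyl on the saturated ring would read in this assay.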